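Halogen swap on the aryl sulfonyl of the piperidinyl-piperidine series

This account rests on a few compounds, and the source may have more. Where it says the series, first, only, none or still open, it means among the compounds named here.

Measured compounds:
compound 1 `CC1CCN(C2CCN(S(=O)(=O)c3ccc(C#N)cc3)CC2)CC1`: 2800 nM
compound 2 `Cc1ccc(S(=O)(=O)N2CCC(N3CCC(C)CC3)CC2)cc1C`: 24 nM
compound 3 `CC1CCN(C2CCN(S(=O)(=O)c3ccc(Br)c(Cl)c3)CC2)CC1`: 12 nM

In a functional assay on DLD-1 cells (Homo sapiens) for antiproliferative activity, read by CellTiter-Glo, with a stated time of 72 h (on this read-out higher numbers stand for weaker inhibition and lower numbers for stronger inhibition), compound 3 gives the lowest of the three numbers; compound 2 sits within the scatter of it, so no order between the two is claimed, while compound 1 lies far above both. The unmeasured compound 4 `CC1CCN(C2CCN(S(=O)(=O)c3ccc(Cl)cc3Cl)CC2)CC1` keeps the core of compound 3 and changes only the aryl group: 2,4-dichlorophenyl in place of 4-bromo-3-chlorophenyl on a sulfonyl sulfur.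

Going by the values given here, no measured step matches this exact change. The step of a 2.0-fold lower number from compound 2 to compound 3 (0.30 log units; within the scatter) shows that exchanging one disubstituted phenyl for another can leave the number within the scatter, whereas a 230-fold lower number from compound 1 to compound 3 (2.37 log units; beyond the scatter) and a 120-fold lower number from compound 1 to compound 2 (2.07 log units; beyond the scatter) show that a 4-cyanophenyl stands apart. Since compound 4 keeps two halogens, the expected step is a 1.8-fold higher number from compound 3 to compound 4 (0.26 log units; within the scatter), within or near the scatter. Compound 4 is therefore estimated at 22 nM, range 7 nM to 70 nM.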

Compound 4, half-maximal inhibitory concentration: 1 nM
For compound 4 the middle estimate is 22-fold (1.34 log units) above the measured one; measured number below the stated range.
By their numbers in this assay, from the lowest: compound 4; then compounds 3 and 2 (each within the scatter of the next); then compound 1.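

In this assay, the aryl group on a sulfonyl sulfur proves more sensitive than the earlier disubstituted phenyls suggested: a 12-fold lower number from compound 3 to compound 4 (1.08 log units; beyond the scatter), so carrying two halogens does not by itself settle the number. The 2,4-dichlorophenyl also stands clear of the 3,4-dimethylphenyl, a 24-fold lower number from compound 2 to compound 4 (1.38 log units; beyond the scatter), and of the 4-cyanophenyl, a 2800-fold lower number from compound 1 to compound 4 (3.45 log units; beyond the scatter). Nothing at hand gives a measured reason for these steps.

The step from 4-bromo-3-chlorophenyl to 2,4-dichlorophenyl changes both the halogen and its placement, and the compounds shown do not separate the two. Also open, on these data alone, is how a 2,4-difluorophenyl, or a phenyl bearing an amine or a carboxylic acid, would read here.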